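Working notes: ethyl to isopropyl from compound 2

A few compounds are considered here, and "the series" means these few. Any claim that something is new, unique, unknown or untested is made for them only; others in the source may bear on it.

Measured so far in a physicochemical assay for lipophilicity (a higher number here means a more lipophilic compound, a lower number a more polar compound), for this series:
compound 1 `O=C1CN(Cc2ccc(-c3ccc(F)c(CN4CCCCC4)n3)cc2)C(=O)N1CC1CC1` gives 2.8
compound 2 `CCN1C(=O)CN(Cc2ccc(-c3cccc(CN4CCCCC4)n3)cc2)C1=O` gives 1.7
compound 3 `O=C1CN(Cc2ccc(-c3ccc(F)c(CN4CCCCC4)n3)cc2)C(=O)N1CC1CCC1` gives 3.5

Of these three, compound 2 has the lowest number, and both others stand beyond the scatter from it, with compound 1 the nearer and compound 3 the further.

Compound 4 `CC(C)N1C(=O)CN(Cc2ccc(-c3cccc(CN4CCCCC4)n3)cc2)C1=O` is still unmeasured. Its change from compound 2 is methyl in place of hydrogen on a saturated chain carbon bound to an amide-type nitrogen in a ring and a saturated chain carbon and the same difference, cut one bond further out, reads ethyl to isopropyl.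

Within the data shown here, no measured step covers this exact change. The one that bears on it is a number 0.70 log units higher from compound 1 to compound 3 (beyond the scatter) with cyclobutyl in place of cyclopropyl on a saturated chain carbon bound to an amide-type nitrogen in a ring. That step is modest but beyond the scatter. It is only a partial guide, as it swaps one ring for another, and compound 1 and compound 3 also differ from compound 2 in the core.

The estimated step is a number 0.50 log units higher from compound 2 to compound 4 (beyond the scatter) and it is expected to be upward and somewhat smaller than the measured one. In this assay the estimated value for compound 4 is 2.2 with an expected range from 1.8 to 2.7 for this measurement.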

Compound 4, distribution coefficient: 2.2
Compound 4: the middle estimate sits on the measured number at the digits printed, and the stated range covers the measured number.
By their numbers in this assay, from the lowest: compound 2; then compound 4; then compound 1; then compound 3.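

Working notes on the position, in this assay: the change from ethyl to isopropyl gives a number 0.50 log units higher from compound 2 to compound 4 (beyond the scatter) and so shows that one added methyl on a saturated chain carbon bound to an amide-type nitrogen in a ring and a saturated chain carbon is enough to move the number beyond the scatter. The earlier step at this place, a number 0.70 log units higher from compound 1 to compound 3 (beyond the scatter) on the core of compound 1, came from a ring exchange, whereas here the entering group has no ring and the core is that of compound 2, so the series now holds an upward step of each kind, and none of the compounds shown goes against that direction. Nothing at hand gives a measured reason for either step.

Still open, going by these compounds, is whether the number keeps rising with tert-butyl or a longer chain at this place, and how a hydroxyethyl chain or an amine there would read in this assay. Also open, on these data alone, is whether ethyl to isopropyl on the core of compound 1 would give a step of similar size.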